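The compounds below may be only part of what the source reports. "The series", "measured", "known", "first", "only" and "open" are said of these compounds alone.

Measured in a functional assay on MCF7 cells (Homo sapiens) for cytotoxicity, read by MTT assay, with a stated time of 72 h; a higher number here means a weaker inhibitor, a lower number a stronger inhibitor:
compound 1 `CNC(=O)c1cc(Oc2ccc(NC(=O)c3cc(-c4ccc(Cl)cc4)ncn3)cc2F)ccn1`: > 100000 nM
compound 2 `CNC(=O)c1cc(Oc2ccc(NC(=O)c3nccc(-c4ccccc4)n3)cc2)ccn1`: 39100 nM
compound 3 `CNC(=O)c1cc(Oc2ccc(NC(=O)c3cc(-c4ccc(C)cc4)ncn3)cc2)ccn1`: 34600 nM

Compound 1 stands at > 100000 nM, which is a limit and not a number. Compound 2 at 39100 nM and compound 3 at 34600 nM lie within the usual scatter of each other. Compound 4 `CNC(=O)c1cc(Oc2ccc(NC(=O)c3cc(-c4ccc(Br)cc4)ncn3)cc2)ccn1` differs from compound 3 in one place: bromo in place of methyl on an aromatic carbon. This puts bromo in place of methyl on an aromatic carbon, para to a large group. Among the compounds with values here, no measured pair shows this change directly. Compound 1, at > 100000 nM, carries chloro in that place, but it differs elsewhere too, so it is only a loose hint towards a higher number in this assay. The expected step of a 1.3-fold higher number from compound 3 to compound 4 (0.11 log units; within the scatter) is small and may stay within the scatter. Compound 4 is estimated at 45000 nM, with an expected range of 18000 nM to 100000 nM.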

Compound 4, half-maximal inhibitory concentration: > 100000 nM
Compound 4 ended at the assay's limit; the forecaster's own chance of this, stated with the estimate: 25%; middle value at least 2.2-fold (0.34 log units) from the limit.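

In this assay, within the data shown here, this is the first direct reading of bromo in place of methyl at this position: an at least 2.8-fold higher number from compound 3 to compound 4 (0.46 log units; beyond the scatter). Changing 4-methylphenyl to 4-bromophenyl, with the rest of the molecule untouched, is enough to move the result beyond the scatter, whereas compound 1 differs elsewhere too and gave only a loose hint. The full size of the step cannot be read, as compound 4 sits at a limit and not a number: the limit of > 100000 nM in this assay, at which 2 of the 4 values shown sit.

From the compounds shown here alone, whether a methoxy group or an amine in this place would stay near compound 3 or also reach the limit remains open.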